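Aryl swap on the side-chain nitrogen of the shared core

A few compounds are considered here, and "the series" means these few. Any claim that something is new, unique, unknown or untested is made for them only; others in the source may bear on it.

The series shares one core, with a dialkylamino-type side chain on one side and a dimethylamino-pyridine on the other. Compound 1 `CCCN(CCC)c1cc(C)nc2c(-c3ccc(N(C)C)nc3)c(C)nn12` gives 4.2 nM in an assay on CHO cells for binding affinity to corticotropin-releasing factor receptor 1 (Homo sapiens); on this read-out lower numbers stand for stronger inhibition and higher numbers for weaker inhibition. Compound 2 `CCCCN(CC)c1cc(C)nc2c(-c3cnc(N(C)C)cc3C)c(C)nn12` gives 2.6 nM in this assay, and compound 3 `CCN(Cc1cccc(C)c1)c1cc(C)nc2c(-c3cnc(N(C)C)cc3C)c(C)nn12` gives 2.4 nM. Compound 3 carries the lowest of the three numbers, but its gap to compound 2 and to compound 1 both stay within the scatter, so no order among the three can be read from these values.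

The step to compound 4 `CCN(Cc1ccccc1F)c1cc(C)nc2c(-c3cnc(N(C)C)cc3C)c(C)nn12` is 2-fluorophenyl in place of 3-methylphenyl on a saturated chain carbon bound to a nitrogen on an aromatic ring. Within the data shown here, the one measured step that touches this position, a 1.1-fold lower number from compound 2 to compound 3 (0.03 log units; within the scatter), exchanged a chain for an aryl group and moved the number by nothing beyond the scatter. Among the measured compounds shown here, an aryl-to-aryl exchange at the same position has no measured counterpart, so nothing in the data points to a shift in either direction.

For compound 4 the expectation in this assay is therefore 3 nM, with a range of 1.2 nM to 7.5 nM. The step this estimate implies is a 1.3-fold higher number from compound 3 to compound 4 (0.10 log units; within the scatter), expected to remain within the scatter.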

Compound 4, inhibition constant: 3.4 nM
The estimate for compound 4 lay 1.1-fold (0.05 log units) below the measured number; the range from low to high includes it.
By their numbers in this assay, from the lowest: compounds 3, 2, 4 and 1 (each within the scatter of the next).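

The position on a saturated chain carbon bound to a nitrogen on an aromatic ring now has an aryl-to-aryl exchange: in this assay, 2-fluorophenyl in place of 3-methylphenyl gives a 1.4-fold higher number from compound 3 to compound 4 (0.15 log units; within the scatter) and so stays inside the scatter. The same holds for 2-fluorophenyl in place of propyl, with a 1.3-fold higher number from compound 2 to compound 4 (0.12 log units; within the scatter) alongside the earlier 1.1-fold lower number from compound 2 to compound 3 (0.03 log units; within the scatter) as the other chain-to-aryl exchange. Across propyl, 3-methylphenyl and 2-fluorophenyl, then, this position shows no step beyond the scatter, including when a fluorine-bearing aryl group replaces one of carbon only. No supporting measurement is available that would explain this flat result.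

From the compounds shown here alone, whether this position tolerates everything or only uncharged groups without hydrogen-bond donors stays open, and a carboxylic acid, a primary amine or a longer chain such as octyl would test that. Compound 1 differs from the other compounds in more than one place, so the contribution of the pyridine substitution cannot be separated from that of the side chain.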